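A few compounds are considered here, and "the series" means these few. Any claim that something is new, unique, unknown or untested is made for them only; others in the source may bear on it.

Measured compounds:
- compound 1 `COc1cc(NC(=O)Nc2cc(Nc3cccc(C(C)(C)C)c3)ncn2)cc(OC)c1`: 13.1%
- compound 2 `COc1cc(Br)ccc1Nc1cc(NC(=O)Nc2c(Cl)cccc2Cl)ncn1`: 29.1%

Both compounds were tested in a functional assay on NCI-H520 cells (Homo sapiens) for inhibition, read by MTT assay, with a stated time of 48 h, tested at 10 uM; on this read-out higher numbers stand for more inhibition at the one concentration tested (going by the name of the read-out) and lower numbers for less inhibition. Compound 1 gives 13.1%, the lowest of the two numbers recorded. Compound 2 gives 29.1%, which lies higher than compound 1 by more than the usual scatter of repeated measurements, so these two do differ. Among the compounds with values here, no pair of measured compounds differs in only one place, so there is no directly measured step to lean on.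

Compound 3 `CCc1cccc(Nc2cc(NC(=O)Nc3cc(OC)cc(OC)c3)ncn2)c1` has not yet been measured. It differs from compound 1 in one place: ethyl in place of tert-butyl on an aromatic carbon. The change swaps one small hydrocarbon group for a slightly smaller one on the same aromatic carbon, with no ring, donor, acceptor or charge gained or lost. Within the data shown here, nothing among the measured compounds shows how such a swap moves this read-out. The most cautious view is that the step in this assay from compound 1 to compound 3 stays within the scatter, in either direction, with no clear gain or loss expected.

On that basis the expected step of a number 1.9 percentage points higher from compound 1 to compound 3 (within the scatter) is small. Compound 3 is therefore estimated to give 15%, with a range from 2% to 32%.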

Compound 3, a percentage reported as inhibition, at one concentration (the size of the read-out at that concentration, not a potency): 23%
Compound 3: middle estimate off by 8 percentage points, on the low side, and the stated range covers the measured number.
By their numbers in this assay, from the lowest: compounds 1, 3 and 2 (each within the scatter of the next, the first and the last beyond it).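

Within the data shown here, replacing tert-butyl with ethyl on this aromatic carbon, meta to a large group, provides the first directly measured step in this assay, and it is a number 9.9 percentage points higher from compound 1 to compound 3 (within the scatter). The position therefore accepts the smaller of these two hydrocarbon groups with no clear gain or loss of inhibition at the single concentration tested, although this one pair cannot show a trend with group size. No measurement of any property of these groups bears on this result, so the data offer no explanation for the step.

From the compounds shown here alone, it remains open whether a group of another kind on this carbon, such as an amine or a carboxylic acid, would move the read-out beyond the usual scatter, or whether a longer chain such as hexyl would do so. It is also unclear whether the same swap would give a similar step in a compound with different groups elsewhere on the shared core, since a single pair cannot show whether the result carries over to other compounds.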